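The source may report more compounds than this note shows. Statements on the series, on what has been measured and on what is new or still open speak of the compounds shown alone.

Within the data shown here, compound 1, `COc1ncnc2c1c(-c1cccs1)cn2[C@@H]1O[C@H](CO)[C@@H](O)[C@H]1O`, is the only member of this small set with a numerical result: in an ADME assay on MRC5 cells (Homo sapiens), read by MTT assay, with a stated time of 72 h (on this read-out lower numbers stand for stronger inhibition and higher numbers for weaker inhibition), compound 1 gives 43200 nM. Compound 2, `COc1nc(N)nc2c1c(-c1cccs1)cn2[C@@H]1O[C@H](CO)[C@@H](O)[C@H]1O`, reaches only a limit of this assay, > 100000 nM. Compound 3, `Nc1nc(N)c2c(-c3cccs3)cn([C@@H]3O[C@H](CO)[C@@H](O)[C@H]3O)c2n1`, likewise reaches only a limit, > 100000 nM. Among the measured compounds shown here, the step of an at least 2.3-fold higher number from compound 1 to compound 2 (0.36 log units; beyond the scatter) is the one readable change here, while the step that the two limits leave unreadable from compound 2 to compound 3 cannot be sized. Compound 2 therefore stands at the limit, as described by the limit of > 100000 nM in this assay, at which 2 of the 3 values shown sit, and nothing in the numbers places it more precisely.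

Compound 4, `COc1nc(N)nc2c1c(-c1ccco1)cn2[C@@H]1O[C@H](CO)[C@@H](O)[C@H]1O`, differs from compound 2 by furan-2-yl in place of thiophen-2-yl on an aromatic carbon. For the measured compounds named here, no measured step in this set concerns this exchange of one five-membered aromatic ring with one hetero atom for another, so no direct guide exists. Given that compound 2 sits at > 100000 nM, compound 4 is expected to show no step beyond the scatter, with the change a step that the limit leaves unreadable from compound 2 to compound 4 anticipated to be small. Compound 4 is estimated at 120000 nM, within 40000 nM to 400000 nM.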

Compound 4, half-maximal inhibitory concentration: 89700 nM
Compound 4: middle estimate off by 1.3-fold (0.13 log units), on the high side; measured number inside the range.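

Among these compounds, compound 4 gives the second numerical result of the set, 89700 nM in this assay, and the first number for a compound that carries both the methoxy and the amino group of compound 2. The exchange of rings on this aromatic carbon gives an at least 1.1-fold lower number from compound 2 to compound 4 (0.04 log units; that floor lies within the scatter), so a lower number is not established, while a larger step is not excluded either. The true size of the step stays unreadable because compound 2 has only a limit: the limit of > 100000 nM in this assay, at which 2 of the 4 values shown sit.

The compounds shown leave open how a phenyl ring, a pyridin-3-yl ring or a small chain such as ethyl would read on this aromatic carbon. Also open, from the compounds shown here alone, is whether furan-2-yl would give a readable step on the core of compound 1 or on that of compound 3.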